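A few compounds are considered here, and "the series" means these few. Any claim that something is new, unique, unknown or untested is made for them only; others in the source may bear on it.

Measured so far:

Compound 1 `CC1CC/C(=N\Nc2ccc(F)cc2)c2ncc(C(=O)O)c(=O)n21` — in a functional assay on the whole organism for inhibition, with Rattus norvegicus as the target (a lower number here means that less compound is needed, a higher number that more compound is needed for the effect), compound 1 gives > 1000 umol/kg, a limit of the assay and not a number.
Compound 2 `CC1CC/C(=N\Nc2ccccc2Cl)c2ncc(C(=O)O)c(=O)n21` — in this assay compound 2 gives > 1000 umol/kg, again a limit.
Compound 3 `CC1CC/C(=N\Nc2ccccc2Br)c2ncc(C(=O)O)c(=O)n21` — in this assay compound 3 gives > 320 umol/kg, also a limit.

Compound 3 therefore stands only at a limit, and none of the three values is a number. Two of the three sit at the same limit (the limit of > 1000 umol/kg in this assay, at which 2 of the 3 values shown sit), the third at a different one (the limit of > 320 umol/kg in this assay, at which 1 of the 3 values shown sits). The steps between them, a step that the two limits leave unreadable from compound 1 to compound 2, a step that the two limits leave unreadable from compound 1 to compound 3 and a step that the two limits leave unreadable from compound 2 to compound 3, cannot be read for size or direction because both ends of each are limits.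

Compound 4 `CC1CC/C(=N\Nc2cccc(Br)c2)c2ncc(C(=O)O)c(=O)n21` differs from compound 3 in one place: 3-bromophenyl in place of 2-bromophenyl on an amine nitrogen. Within the data shown here, none of the measured steps concerns a 3-bromophenyl, and the only step touching the bromophenyl, the one from compound 2 to compound 3, is itself unreadable. Among the measured compounds shown here, no size of step in this assay can be derived from the data; the most that can be said is that every change tried so far has left the value at a limit.

Compound 4 is accordingly expected to give about 1000 umol/kg in this assay, within 300 umol/kg to 3000 umol/kg, most likely again only as a limit. The expected step from compound 3 is a step that the limit leaves unreadable from compound 3 to compound 4.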

Compound 4, dose for 50% inhibition: > 320 umol/kg
Compound 4: no number, only a limit (the forecaster's own chance of this, stated with the estimate: 85%); the middle value does not contradict the limit.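

In this assay compound 4 gives > 320 umol/kg, a limit and not a number. Its steps from compound 1, compound 2 and compound 3 cannot be read, as both ends of each are limits. The compounds shown leave open whether 3-bromophenyl and 2-bromophenyl differ at all in this assay, and what dose any of the four compounds actually needs.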